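Nitro Substitution Across Two Core Isomers

This account rests on a few compounds, and the source may have more. Where it says the series, first, only, none or still open, it means among the compounds named here.

Measured compounds in a functional assay on HT-1080 cells (Homo sapiens) for antiproliferative activity, read by MTT assay, with a stated time of 72 h; a lower number here means a stronger inhibitor, a higher number a weaker inhibitor:
- compound 1 `COc1ccc(-c2ssc(=O)c2-c2cc(OC)c(OC)c(OC)c2)cc1`: 464 nM
- compound 2 `COc1ccc(-c2ssc(=O)c2-c2cc(OC)c(OC)c(OC)c2)cc1[N+](=O)[O-]`: 4220 nM
- compound 3 `COc1ccc(-c2c(-c3cc(OC)c(OC)c(OC)c3)ssc2=O)cc1`: > 100000 nM, which is a limit of this assay and not a number

Compound 1 and compound 3 are built from the same atoms joined differently; the difference between the two cores is not broken down here. In this assay compound 1 gives 464 nM. For compound 3 only the limit of > 100000 nM in this assay, at which 1 of the 3 values shown sits, is available, so compound 3 stands at the limit of this assay.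

Compound 2 carries the change nitro in place of hydrogen on an aromatic carbon on the core of compound 1. That change gave a 9.1-fold higher number from compound 1 to compound 2 (0.96 log units; beyond the scatter), so the number rose beyond the scatter.

Compound 4 `COc1ccc(-c2c(-c3cc(OC)c(OC)c(OC)c3)ssc2=O)cc1[N+](=O)[O-]` is not yet measured. It carries nitro in place of hydrogen on an aromatic carbon on the core of compound 3, the same change as from compound 1 to compound 2, at the same place. Because the step of a 9.1-fold higher number from compound 1 to compound 2 (0.96 log units; beyond the scatter) moved the number up, and because compound 3 already sits at the limit of > 100000 nM in this assay, at which 1 of the 3 values shown sits, compound 4 is expected to remain at or beyond that limit. The expected step is a step that the limit leaves unreadable from compound 3 to compound 4. Compound 4 is therefore estimated at 400000 nM, within 100000 nM to 2000000 nM.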

Compound 4, half-maximal inhibitory concentration: > 100000 nM
Compound 4: no number, only a limit (the forecaster's own chance of this, stated with the estimate: 90%); the middle value lies beyond the limit too.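

In this assay compound 4 gives > 100000 nM, which is a limit of the assay and not a number. Compound 3 also stands at a limit, and the step between compound 3 and compound 4 cannot be read. The compounds shown leave open whether nitro in place of hydrogen on an aromatic carbon shifts the number on the core of compound 3 as it does on the core of compound 1.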